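Tetraoxane Sulfonamides: Cytotoxicity on Liver Cells

A few compounds are considered here, and "the series" means these few. Any claim that something is new, unique, unknown or untested is made for them only; others in the source may bear on it.

Compound 1, `O=S(=O)(c1ccc(F)cc1)N1CCC2(CC1)OOC1(CCCCC1)OO2`, in a functional assay on Huh-7 cells (Homo sapiens) for cytotoxicity, read by MTT assay, with a stated time of 72 h (a higher number here means that more compound is tolerated, a lower number that less compound is tolerated), gives > 100 ug/mL, a limit of the assay rather than a number.
Compound 2, `O=S(=O)(c1ccc(F)cc1)N1CCC2(CC1)OOC1(CCCCCC1)OO2`, in this assay gives > 100 ug/mL, again a limit.
Compound 3, `O=S(=O)(c1ccc(Br)cc1F)N1CCC2(CC1)OOC1(CCCCC1)OO2`, in this assay gives > 100 ug/mL, also a limit.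

All three values sit at the limit of > 100 ug/mL in this assay, at which 3 of the 3 values shown sit. The difference between the core of compound 1 and the core of compound 2 is not broken down here. From compound 1 to compound 3 the change is 4-bromo-2-fluorophenyl in place of 4-fluorophenyl on a sulfonyl sulfur, and the step that the two limits leave unreadable from compound 1 to compound 3 cannot be sized, since both ends are limits. The same change, (4-bromo-2-fluorophenyl in place of 4-fluorophenyl on a sulfonyl sulfur), leads from compound 2 to the unmeasured compound 4, `O=S(=O)(c1ccc(Br)cc1F)N1CCC2(CC1)OOC1(CCCCCC1)OO2`. Given that compound 1 and compound 3 both sit at the limit, the step that the limit leaves unreadable from compound 2 to compound 4 is expected to be small. Compound 4 is estimated at 120 ug/mL in this assay, most likely reported again as a limit.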

Compound 4, half-maximal cytotoxic concentration: > 100 ug/mL
Compound 4 was reported as a limit; the forecaster's own chance of this, stated with the estimate: 85%; the middle value is on the limit's open side.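

Compound 2 and compound 4 both stand as limits rather than numbers, so the step between them cannot be read: the limit of > 100 ug/mL in this assay, at which 4 of the 4 values shown sit. The compounds shown leave open at what concentration, if any, each becomes toxic to these cells.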